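The source may hold more compounds than are shown below. What is called first, only, known or untested is meant among the compounds shown, and "the series" means these compounds.

Measured compounds:
- compound 1 `O=c1c2cc([N+](=O)[O-])cnc2sn1-c1ccc([N+](=O)[O-])cc1`: 15800 nM
- compound 2 `Oc1nsc2ncccc12`: "not determined" (no result reported)
- compound 3 `O=C1c2cccnc2S(=O)(=O)N1Cc1ccc(Cl)c(Cl)c1`: "not determined" (no result reported)

In an assay for inhibition of histone acetyltransferase KAT2B (Homo sapiens), read by fluorescence (a higher number here means a weaker inhibitor, a lower number a stronger inhibitor), compound 1 gives 15800 nM, which marks it as a weak inhibitor. Within the data shown here, it is the only compound of the three with a number at all: compound 2 and compound 3 carry no result in this assay, so no step between measured compounds can be drawn, and compound 1 stands alone as the single point of reference.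

The step to compound 4 `O=c1c2cccnc2sn1-c1ccc([N+](=O)[O-])cc1` is a small one on paper. Compared with compound 1, the change is hydrogen in place of nitro on an aromatic carbon, the nitro on the six-membered ring of the shared core being taken away while the nitrophenyl group on the other nitrogen stays.

Among the measured compounds shown here, with no comparable step among the measured compounds, there is nothing to say how much this assay responds to such a removal. Compound 4 is therefore expected to land close to compound 1, with some leaning toward a weaker inhibitor, the expected step being a 1.6-fold higher number from compound 1 to compound 4 (0.20 log units; within the scatter). The estimate for compound 4 is 25000 nM, within a range of 8000 nM to 100000 nM.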

Compound 4, half-maximal inhibitory concentration: 2990 nM
Compound 4: middle estimate off by 8.4-fold (0.92 log units), on the high side; measured number below the stated range.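

Taking away the nitro group and leaving hydrogen on that aromatic carbon gives the first readable step in this assay: a 5.3-fold lower number from compound 1 to compound 4 (0.72 log units; beyond the scatter), a modest change that lies beyond the scatter. This shows that the position, two atoms from the ring nitrogen, does affect the result, and that the nitro group there is not required for inhibition, as compound 4 is the stronger inhibitor of the pair while the nitrophenyl group stays in place. Nothing available explains why the number falls when the nitro group leaves.

As far as these compounds go, at this position, only nitro and hydrogen can be compared, so it remains open whether other groups, such as an amine, a methoxy group or a chlorine atom, would give a lower or a higher number than hydrogen does. The nitrophenyl group also remains untested by any step, and the compounds shown do not reveal what would happen if its nitro were replaced by hydrogen or a carboxylic acid.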